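The source may report more compounds than this note shows. Statements on the series, on what has been measured and on what is new or still open speak of the compounds shown alone.

Notes on the series. Compound 1 is `Oc1ccc(-c2nc3cc(C(F)(F)F)ccc3[nH]2)cc1`; compound 2 is `O=C(CN1CCCC1)Nc1ccc(-c2nc3ccccc3[nH]2)cc1`; compound 3 is `CCN(CC)CC(=O)Nc1ccc(-c2nc3cc(C(F)(F)F)ccc3[nH]2)cc1`. In an ADME assay on Vero cells (Chlorocebus sabaeus) for cytotoxicity (a lower number here means that less compound is tolerated, a higher number that more compound is tolerated), compound 1 gives only a limit, > 100000 nM. In this assay compound 2 likewise gives only a limit, > 100000 nM. In this assay, within the data shown here, compound 3 gives 24000 nM, the only actual number in the set. Among the measured compounds shown here, the one measured step is an at least 4.1-fold lower number from compound 1 to compound 3 (0.61 log units; beyond the scatter), which is at least modest and is anchored on the limit of > 100000 nM in this assay, at which 2 of the 3 values shown sit, rather than on two numbers.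

Compound 4 is `O=C(CN1CCCC1)Nc1ccc(-c2nc3cc(C(F)(F)F)ccc3[nH]2)cc1`. It differs from compound 3 in one place: pyrrolidin-1-yl in place of diethylamino on a saturated chain carbon bound to a carbonyl carbon. For the measured compounds named here, no measured step covers this exchange of one amine for another; the only step recorded concerns the amide attachment itself and does not speak to the ring closure. Compound 2 carries the same pyrrolidin-1-yl group but lacks the trifluoromethyl, and its value is a limit, so it gives no size for comparison. Going by the values given here, with no bearing step, no change beyond the scatter is expected in this assay, in either direction. The estimated step of a 1.2-fold higher number from compound 3 to compound 4 (0.07 log units; within the scatter) reflects this. Compound 4 is therefore expected to give about 28000 nM in this assay, within 10000 nM to 90000 nM.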

Compound 4, half-maximal cytotoxic concentration: > 100000 nM
Compound 4: only a limit was reported (the forecaster's own chance of this, stated with the estimate: 25%); at least 3.5-fold (0.55 log units) between middle value and limit.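

In this assay, among these compounds, the exchange of diethylamino for pyrrolidin-1-yl on a saturated chain carbon bound to a carbonyl carbon is the only measured change at this place, and it gives an at least 4.1-fold higher number from compound 3 to compound 4 (0.61 log units; beyond the scatter). Among the compounds shown here, the amine at the end of the side chain therefore affects this read-out with trifluoromethyl present, even though the two groups have the same count of heavy atoms and differ in that pyrrolidin-1-yl is a five-membered ring; compound 3 remains the only one of the four compounds with an actual number. The size of the step rests on a limit rather than on two numbers: the limit of > 100000 nM in this assay, at which 3 of the 4 values shown sit.

The steps from compound 2 to compound 4 and from compound 1 to compound 4 cannot be read, so the exchange of hydrogen for trifluoromethyl has no measured size here. Going by these compounds, it remains open whether another amine at this place, such as dimethylamino or piperidin-1-yl, would give a number like that of compound 3 or a limit like that of compound 4, and whether diethylamino without trifluoromethyl would give a number at all.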